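The compounds below may be only part of what the source reports. "The series", "measured", "known", "first", "only" and "open" are said of these compounds alone.

In an assay on membranes from CHO cells for displacement of a labelled ligand from adenosine receptor A1 (Homo sapiens), read by scintillation counting, with a stated time of 60 min, tested at 1 uM (a higher number here means more inhibition at the concentration tested (going by the name of the read-out), a lower number less inhibition), compound 3 `CC1=C(C(=O)OC2CCC2)C(c2ccoc2)NC(=O)N1` gives 20%, which stands highest of the three numbers shown, though only one of its two gaps lies beyond the scatter. Compound 1 `CC1=C(C(=O)OC(C)(C)C)C(c2ccoc2)NC(=O)N1` gives 11% and compound 2 `CCNC(=O)C1=C(C)NC(=O)NC1c1ccoc1` gives 1%. The steps among them read a number 10 percentage points lower from compound 1 to compound 2 (within the scatter), a number 9 percentage points higher from compound 1 to compound 3 (within the scatter) and a number 19 percentage points higher from compound 2 to compound 3 (beyond the scatter). Compound 4 `CC1=C(C(=O)OCC2CCC2)C(c2ccoc2)NC(=O)N1` has not yet been measured; it differs from compound 3 by cyclobutylmethyl in place of cyclobutyl on an oxygen next to a carbonyl group. The step that bears most directly on this change is the one on the same oxygen, a number 9 percentage points higher from compound 1 to compound 3 (within the scatter), where exchanging one alkyl group for another left the number within the scatter. The two steps of a number 10 percentage points lower from compound 1 to compound 2 (within the scatter) and a number 19 percentage points higher from compound 2 to compound 3 (beyond the scatter) concern the group on the carbonyl carbon instead and speak less directly to the present change. On this basis no movement beyond the scatter is expected, no change at the digits printed from compound 3 to compound 4 (within the scatter). Compound 4 is therefore estimated at 20%, with a likely range from 5% to 38%.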

Compound 4, a percentage reported as inhibition, at one concentration (the size of the read-out at that concentration, not a potency): 46%
The estimate for compound 4 lay 26 percentage points below the measured number; the measured number lies above the stated range.
By their numbers in this assay, from the lowest: compounds 2, 1 and 3 (each within the scatter of the next, the first and the last beyond it); then compound 4.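

In this assay, cyclobutylmethyl in place of cyclobutyl on an oxygen next to a carbonyl group gives a number 26 percentage points higher from compound 3 to compound 4 (beyond the scatter) and so shows that this position can respond beyond the scatter, which the earlier exchange on the same oxygen, a number 9 percentage points higher from compound 1 to compound 3 (within the scatter), did not show. The gain also holds against the other two compounds, with a number 35 percentage points higher from compound 1 to compound 4 (beyond the scatter) for the exchange of tert-butyl on that oxygen and a number 45 percentage points higher from compound 2 to compound 4 (beyond the scatter) for cyclobutylmethoxy in place of ethylamino on a carbonyl carbon, which places compound 4 highest of the four. Nothing measured here accounts for this gain.

From the compounds shown here alone, whether a longer chain between the oxygen and the cyclobutyl ring, or a cyclopentylmethyl group on the same oxygen, would raise the number further remains open. So does whether cyclobutylmethylamino on the carbonyl carbon would match cyclobutylmethoxy.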